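The source may hold more compounds than are shown below. What is called first, only, known or untested is meant among the compounds shown, and "the series" means these compounds.

Measured so far in an ADME assay on Vero cells (Chlorocebus sabaeus) for cytotoxicity, read by luminescence, with a stated time of 2 days; a lower number here means that less compound is tolerated, a higher number that more compound is tolerated:
- compound 1, `Cc1nc2ccccc2n1CCCCOc1ccccc1`; compound 1 gives > 50 uM, a limit of the assay and not a number
- compound 2, `CCc1nc2ccccc2n1CCCCOCc1ccccc1`; compound 2 gives 32 uM
- compound 3, `CCc1nc2ccccc2n1CCCCOc1cccc(Cl)c1`; compound 3 gives 22 uM

Compound 2 holds the higher of the two numbers, with compound 3 nearest: a 1.5-fold lower number from compound 2 to compound 3 (0.16 log units; within the scatter), so the two are not separable. The remaining entry is a limit, and compound 1 sits at the limit of > 50 uM in this assay, at which 1 of the 3 values shown sits.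

Not yet measured is compound 4, `CCc1nc2ccccc2n1CCCCOc1ccc(Cl)cc1C`. Against compound 2 the change is 4-chloro-2-methylphenyl in place of benzyl on an oxygen on a saturated carbon. Within the data shown here, one measured step touches the same place: a 1.5-fold lower number from compound 2 to compound 3 (0.16 log units; within the scatter), where 3-chlorophenyl replaced benzyl on the oxygen on a saturated carbon and the number moved only within the scatter. Compound 4 likewise exchanges benzyl for a chlorine-bearing phenyl, here 4-chloro-2-methylphenyl, so the nearest guide is that step. The expectation in this assay is therefore no step beyond the scatter, at most a small drift toward a lower number as seen for compound 3, giving a 1.5-fold lower number from compound 2 to compound 4 (0.16 log units; within the scatter) from compound 2. Compound 4 is estimated at 22 uM, expected between 9 uM and 50 uM.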

Compound 4, half-maximal toxic concentration: 20 uM
The estimate for compound 4 lay 1.1-fold (0.04 log units) above the measured number, and the stated range covers the measured number.
By their numbers in this assay, from the lowest: compounds 4, 3 and 2 (each within the scatter of the next). At a limit, above all of these: compound 1.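

In this assay the oxygen on a saturated carbon now carries a second chlorine-bearing phenyl, 4-chloro-2-methylphenyl, and the exchange for benzyl gives a 1.6-fold lower number from compound 2 to compound 4 (0.20 log units; within the scatter) and so again stays inside the scatter. Exchanging one chlorine-bearing group for the other gives a 1.1-fold lower number from compound 3 to compound 4 (0.04 log units; within the scatter), which leaves 3-chlorophenyl and 4-chloro-2-methylphenyl unseparated, and none of the three groups compared at this place, benzyl included, is set apart from the others by a step beyond the scatter. The compounds shown offer no measurement that explains why these steps stay so small.

As far as these compounds go, whether an amine or a carboxylic acid on the phenyl, or a longer chain in place of the present saturated chain, would give a step beyond the scatter remains open. Among these compounds, compound 1 gives > 50 uM, a limit of the assay and not a number, and no step from it can be read.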